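Trifluoromethyl to hydrogen on the phenyl group

This account rests on a few compounds, and the source may have more. Where it says the series, first, only, none or still open, it means among the compounds named here.

- Compound 1 `CNC(=O)c1cc(Oc2ccc(NC(=O)c3nn(-c4ccccc4Cl)c(=O)cc3C)cc2F)ccn1`: 11800 nM
- Compound 2 `CNC(=O)c1cc(Oc2ccc(NC(=O)c3nn(-c4cccc(C(F)(F)F)c4)c(=O)cc3C)cc2F)ccn1`: 10200 nM

Among the measured compounds shown here, in a functional assay on A549 cells (Homo sapiens) for antiproliferative activity, read by MTT assay, with a stated time of 72 h (a lower number here means a stronger inhibitor, a higher number a weaker inhibitor), compound 2 cannot be told apart from compound 1, the only other measured compound: a 1.2-fold lower number from compound 1 to compound 2 (0.06 log units; within the scatter). Compound 3 `CNC(=O)c1cc(Oc2ccc(NC(=O)c3nn(-c4ccccc4)c(=O)cc3C)cc2F)ccn1` differs from compound 2 in one place: hydrogen in place of trifluoromethyl on an aromatic carbon. For the measured compounds named here, that single measured step also exchanged a group on the aromatic ring and stayed small, but no measured compound carries plain phenyl, so the expectation is uncertain. No step beyond the scatter is expected. The estimate means a 1.1-fold higher number from compound 2 to compound 3 (0.03 log units; within the scatter). For compound 3 the expected value is 11000 nM, with an estimated range of 5000 nM to 25000 nM.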

Compound 3, half-maximal inhibitory concentration: 40800 nM
For compound 3 the middle estimate is 3.7-fold (0.57 log units) below the measured one; the measured number lies above the stated range.
By their numbers in this assay, from the lowest: compounds 2 and 1 (each within the scatter of the next); then compound 3.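

In this assay having a group on this phenyl ring matters: the number rises with a 4.0-fold higher number from compound 2 to compound 3 (0.60 log units; beyond the scatter) when trifluoromethyl gives way to hydrogen and with a 3.5-fold higher number from compound 1 to compound 3 (0.54 log units; beyond the scatter) when chloro gives way to hydrogen. Compound 1 and compound 2 could not be told apart, so among these three compounds only the plain phenyl of compound 3 stands out. No measurement shown gives a reason for this.

Going by these compounds, whether other groups on this ring would match chloro and trifluoromethyl remains open. A methoxy group or an amine here would help test that.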